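Whole-animal series: methyl on the phenyl ring

A few compounds are considered here, and "the series" means these few. Any claim that something is new, unique, unknown or untested is made for them only; others in the source may bear on it.

Measured so far:
compound 1 `Cc1nnc(C)n1/N=C(\N)c1ccccc1` — > 600 mg/kg
compound 2 `CC(=O)n1nc(-c2ccccc2)nc1C` — 439 mg/kg

In a functional assay on the whole organism with Mus musculus as the target (on this read-out lower numbers stand for an effect already at smaller amounts and higher numbers for an effect only at larger amounts of compound), compound 2 gives 439 mg/kg. Compound 1 reaches only (the limit of > 600 mg/kg in this assay, at which 1 of the 2 values shown sits), which is a limit of the assay and not a number. Compound 2 therefore holds the only number shown; the other entry is a limit.

Compound 3 `CC(=O)n1nc(-c2ccc(C)cc2)nc1C` differs from compound 2 by methyl in place of hydrogen on an aromatic carbon. For the measured compounds named here, no step between two measured compounds exists for comparison, so no shift beyond the usual scatter is expected in this assay. Compound 3 is estimated at 420 mg/kg, with 200 mg/kg to 800 mg/kg as the range, an expected step of a 1.0-fold lower number from compound 2 to compound 3 (0.02 log units; within the scatter).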

Compound 3, dose for 50% inhibition: > 600 mg/kg
Compound 3 was reported as a limit; the forecaster's own chance of this, stated with the estimate: 30%; middle value at least 1.4-fold (0.15 log units) away from the limit.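

Methyl in place of hydrogen on the aromatic carbon gives the first readable step in this assay: an at least 1.3-fold higher number from compound 2 to compound 3 (0.13 log units; that floor lies within the scatter). Compound 3 gives > 600 mg/kg, which is a limit of the assay and not a number, so no lower number comes with this methyl and the true size of the step stays unread. Limits now outnumber numbers among the compounds shown: the limit of > 600 mg/kg in this assay, at which 2 of the 3 values shown sit.

Open, as far as these compounds go, is whether a different group at this place, such as an amine or a carboxylic acid, would give a number in this assay. Also open, from the compounds shown here alone, is whether a longer chain in place of methyl would behave as methyl does.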